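Basic amide tails against glutathione S-transferase P

A few compounds are considered here, and "the series" means these few. Any claim that something is new, unique, unknown or untested is made for them only; others in the source may bear on it.

Measured compounds:
compound 1 `Cc1ccc(NC(=O)CCC(=O)OCCCCCCSc2ccc([N+](=O)[O-])c3nonc23)cc1` — in an assay on isolated protein for inhibition of glutathione S-transferase P (Homo sapiens), with a stated time of 10 min (a higher number here means a weaker inhibitor, a lower number a stronger inhibitor), compound 1 gives 6800 nM
compound 2 `O=C(CCC(=O)OCCCCCCSc1ccc([N+](=O)[O-])c2nonc12)Nc1ccc(C(F)(F)F)cc1` — in this assay compound 2 gives 5050 nM
compound 3 `CN(C)CCCNC(=O)CCC(=O)OCCCCCCSc1ccc([N+](=O)[O-])c2nonc12` — in this assay compound 3 gives 160 nM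

Compound 3 has the lowest number of the three. Its nearest neighbour is compound 2, with a 32-fold lower number from compound 2 to compound 3 (1.50 log units; beyond the scatter); the furthest is compound 1, with a 43-fold lower number from compound 1 to compound 3 (1.63 log units; beyond the scatter). The step of a 1.3-fold lower number from compound 1 to compound 2 (0.13 log units; within the scatter) between the two aryl amides is small. Both large steps came from exchanging an aryl group on the amide nitrogen for an amine-bearing chain.

Compound 4 `O=C(CCC(=O)OCCCCCCSc1ccc([N+](=O)[O-])c2nonc12)NCCN1CCCC1` keeps that amine-bearing chain and alters only its shape: pyrrolidin-1-yl in place of (dimethylamino)methyl on a saturated chain carbon, two bonds along the chain from an amide-type nitrogen. Going by the values given here, none of the measured steps touches this part of the molecule; the steps to compound 3 each replaced an aromatic ring with a basic chain, which is not what happens here. Since the amine tail that distinguished compound 3 from compounds 1 and 2 is retained, the step from compound 3 to compound 4 is expected to stay within the scatter: a 1.3-fold higher number from compound 3 to compound 4 (0.10 log units; within the scatter). Compound 4 is therefore estimated at 200 nM in this assay, with a range from 70 nM to 600 nM.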

Compound 4, half-maximal inhibitory concentration: 460 nM
Estimate against measurement, compound 4: 2.3-fold (0.36 log units) below; the measured number falls inside the stated range.
By their numbers in this assay, from the lowest: compound 3; then compound 4; then compounds 2 and 1 (each within the scatter of the next).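

Replacing 3-(dimethylamino)propyl with 2-(pyrrolidin-1-yl)ethyl on the amide-type nitrogen gave a 2.9-fold higher number from compound 3 to compound 4 (0.46 log units; beyond the scatter) in this assay, so this position responds to changes within the amine-bearing chain as well as to the exchange of an aryl group for such a chain. The new tail still retained much of the advantage over the aryl amides, with an 11-fold lower number from compound 2 to compound 4 (1.04 log units; beyond the scatter) and a 15-fold lower number from compound 1 to compound 4 (1.17 log units; beyond the scatter). Nothing available explains these differences.

The change altered both the amine and the chain that carries it, so these compounds cannot show whether the pyrrolidine ring or the move from propyl to ethyl accounts for the step. A 2-(dimethylamino)ethyl or 3-(pyrrolidin-1-yl)propyl group on the same nitrogen would separate the two.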